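Replacing a Methoxy-Methylphenyl Group with Ethyl on the Ring Nitrogen

The compounds below may be only part of what the source reports. "The series", "measured", "known", "first", "only" and "open" are said of these compounds alone.

Measured compounds:
Compound 1: `COc1ccccc1N1C(=O)CSC1c1cc(F)cc(C(=O)O)c1` gives 8%
Compound 2: `COc1ccc(C)cc1N1C(=O)CSC1c1cccc(C(=O)NCCCCc2ccccc2)c1` gives 42%

Both compounds were tested in a functional assay on HOS cells (Homo sapiens) for inhibition, read by CCK-8 assay, with a stated time of 72 h, tested at 1 uM; on this read-out higher numbers stand for more inhibition at the one concentration tested (going by the name of the read-out) and lower numbers for less inhibition. Compound 2 stands highest of the two numbers; its nearest neighbour is compound 1, which lies lower by a margin beyond the usual scatter. Among the compounds with values here, compound 1 and compound 2 differ in more than one place, so no single step between them can be read, and only their two values can be compared.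

The next compound, compound 3 `CCN1C(=O)CSC1c1cccc(C(=O)NCCCCc2ccccc2)c1`, has not yet been measured in this assay. It is derived from compound 2 by one change: ethyl in place of 2-methoxy-5-methylphenyl on an amide-type nitrogen in a ring. The change removes a ring-bearing group from the shared core and leaves a short chain in its place.

Within the data shown here, no measured pair shows the effect of this kind of change, so the expectation rests on compound 2 alone. Compound 3 is expected to lose some inhibition, with a step of a number 22 percentage points lower from compound 2 to compound 3 (beyond the scatter) in this assay. Compound 3 is therefore estimated at 20%, within a range from 0% to 45%.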

Compound 3, a percentage reported as inhibition, at one concentration (the size of the read-out at that concentration, not a potency): 6%
The estimate for compound 3 lay 14 percentage points above the measured number, within the range that was stated.
By their numbers in this assay, from the lowest: compounds 3 and 1 (each within the scatter of the next); then compound 2.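

In this assay, within the data shown here, putting ethyl in place of 2-methoxy-5-methylphenyl on the amide-type nitrogen in the ring gives a step of a number 36 percentage points lower from compound 2 to compound 3 (beyond the scatter), and this is the first comparison here in which only one place on the molecule changes. It shows that the group on this nitrogen has a large influence on the inhibition seen at the one concentration tested, even with the rest of the molecule held the same, and that the ethyl, a small group with no ring, does not keep the level reached with the 2-methoxy-5-methylphenyl group. Nothing measured here explains the drop.

With only these two groups compared on this nitrogen, the compounds shown leave open whether the difference comes from the aromatic ring itself, from its methoxy group or from its methyl group. From the compounds shown here alone, it also remains open whether a plain phenyl, a benzyl or a longer chain such as hexyl at this position would sit nearer to compound 2 or to compound 3.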